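From methoxycarbonyl to methylcarbamoyl: expected clearance of compound 4

The source may hold more compounds than are shown below. What is called first, only, known or untested is meant among the compounds shown, and "the series" means these compounds.

Three compounds have been measured in an in vitro ADME assay on microsomes from liver (Homo sapiens) for metabolic stability, tested at 1 uM (on this read-out lower numbers stand for slow clearance and higher numbers for fast clearance), so far:
Compound 1 `Cc1cc(CCC#N)cc(C)c1Oc1cc(Nc2ccc(C#N)cc2)c(N)cc1C(F)(F)F` gives 120 mL.min-1.g-1
Compound 2 `COC(=O)c1cc(N)c(Nc2ccc(C#N)cc2)cc1Oc1c(C)cc(CCC#N)cc1C` gives 40 mL.min-1.g-1
Compound 3 `COC(=O)c1cc(N)c(Nc2ccc(C#N)cc2)cc1Oc1c(C)cc(/C=C/C#N)cc1C` gives 20 mL.min-1.g-1

Compound 3 lies within the scatter of compound 2 at the low end of these numbers, while compound 1 stands clearly higher. Compound 4 `CNC(=O)c1cc(N)c(Nc2ccc(C#N)cc2)cc1Oc1c(C)cc(/C=C/C#N)cc1C` differs from compound 3 in a single group (methylamino in place of methoxy on a carbonyl carbon): methylamino in place of methoxy on a carbonyl carbon, which turns methoxycarbonyl into methylcarbamoyl.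

Going by the values given here, two measured steps bear on this change. The more relevant one involves the same group: putting methoxycarbonyl in place of trifluoromethyl gave a modest shift (a 3.0-fold lower number from compound 1 to compound 2 (0.48 log units; beyond the scatter)). The other, 2-cyanoethenyl in place of 2-cyanoethyl, concerns a different group and gave no shift beyond the scatter (a 2.0-fold lower number from compound 2 to compound 3 (0.30 log units; within the scatter)). Among the compounds with values here, neither step swaps methoxy for methylamino, and no measured compound carries methylcarbamoyl, so the data offer no direct guide. Starting from compound 3 (20 mL.min-1.g-1), no clear shift is expected in this assay, only a slight lean toward a lower number. The expected step is small (a 1.3-fold lower number from compound 3 to compound 4 (0.12 log units; within the scatter)) and is estimated to stay within the scatter. For compound 4 the estimated value is 15 mL.min-1.g-1 with an expected range from 6 mL.min-1.g-1 to 35 mL.min-1.g-1 as the likely span.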

Compound 4, intrinsic clearance in microsomes: 150 mL.min-1.g-1
Beside the measured number, compound 4's estimate is 10-fold (1.00 log units) below it, and the stated range ends below it.
By their numbers in this assay, from the lowest: compounds 3 and 2 (each within the scatter of the next); then compounds 1 and 4 (each within the scatter of the next).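

In this assay, going by these compounds alone, methylamino in place of methoxy on a carbonyl carbon gives a 7.5-fold higher number from compound 3 to compound 4 (0.88 log units; beyond the scatter), the first step toward a higher number and a larger one than either earlier step. The earlier steps shown here replaced a whole group or altered the cyano-bearing chain, whereas here the carbonyl stays in place and only what is attached to it changes, from a methoxy oxygen to a methylamino nitrogen that carries a hydrogen-bond donor; clearance at this position therefore depends on more than the presence of a carbonyl group. Within the data shown here, no measurement available here explains why this small exchange moves the number so far.

The compounds shown do not separate the role of the amide hydrogen from that of the nitrogen itself; a dimethylamino group on the same carbonyl carbon, which has no such hydrogen, would bear on that question, and a plain amino group or an ethoxy group would show how much the outer part matters. From the compounds shown here alone, it also remains open whether the same exchange would give a step of similar size with 2-cyanoethyl in place of 2-cyanoethenyl.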